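Replacing a Urea Nitrogen with a Direct Aryl Link

The compounds below may be only part of what the source reports. "The series", "measured", "known", "first", "only" and "open" are said of these compounds alone.

Of the compounds shown here, two built on the same core have been measured in a functional assay on MDA-MB-435 cells (Homo sapiens) for inhibition, read by sulforhodamine B assay, with a stated time of 48 h; on this read-out higher numbers stand for weaker inhibition of growth and lower numbers for stronger inhibition of growth. Compound 1 `COc1cc(-c2nn(-c3cccc(NC(=O)Nc4ccc(Cl)c(Cl)c4)c3)cc2-c2ccncc2)ccc1Cl` gives 938 nM. Compound 2 `COc1cc(-c2nn(-c3cccc(NC(=O)Nc4cccc(C(F)(F)F)c4)c3)cc2-c2ccncc2)ccc1Cl` gives 866 nM. Going by the values given here, the one step between them, a 1.1-fold lower number from compound 1 to compound 2 (0.03 log units; within the scatter), is a swap of the aryl group on the amide-type nitrogen. Compound 2 therefore stands at the lowest of the two numbers, but only by a margin that the scatter of the assay swallows, so neither compound can be called the stronger.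

Compound 3 `COc1cc(-c2nn(-c3cccc(NC(=O)c4ccc(Cl)c(C(F)(F)F)c4)c3)cc2-c2ccncc2)ccc1Cl` is the next candidate. It differs from compound 2 in that (4-chloro-3-(trifluoromethyl)phenyl in place of (3-(trifluoromethyl)phenyl)amino on a carbonyl carbon). This is a change of a different kind from the measured step: the nitrogen that carried the hydrogen-bond donor leaves, and the aryl ring now sits directly on the carbonyl carbon. Among the compounds with values here, the single measured step, a 1.1-fold lower number from compound 1 to compound 2 (0.03 log units; within the scatter), changed only the aryl group and bears on this only loosely. With nothing that shows the weight of the lost donor, compound 3 is expected to land near compound 2, with a 1.5-fold higher number from compound 2 to compound 3 (0.18 log units; within the scatter) as the estimated step. Compound 3 is thus estimated at 1300 nM, with a range from 400 nM to 4500 nM.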

Compound 3, concentration for 50% growth inhibition: 664 nM
For compound 3 the middle estimate is 2.0-fold (0.29 log units) above the measured one, and the stated range covers the measured number.
By their numbers in this assay, from the lowest: compounds 3, 2 and 1 (each within the scatter of the next).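

In this assay, the exchange on the carbonyl carbon of (3-(trifluoromethyl)phenyl)amino for 4-chloro-3-(trifluoromethyl)phenyl amounts to only a small step (a 1.3-fold lower number from compound 2 to compound 3 (0.12 log units; within the scatter)), so this position accepts a direct aryl link in place of the urea nitrogen with no change that the read-out can separate from scatter. The comparison with the dichlorophenyl urea reads the same way (a 1.4-fold lower number from compound 1 to compound 3 (0.15 log units; within the scatter)), which extends the finding from a swap of aryl groups alone to a swap that also removes the nitrogen and its hydrogen-bond donor. The step from compound 2 to compound 3 also brings in a chlorine, however, so the loss of the nitrogen cannot be read apart from that addition. No measurement is available that accounts for this outcome or shows what the lost donor contributes. The compounds shown leave open whether the direct link would hold with an aryl ring carrying neither chlorine nor trifluoromethyl, such as a plain phenyl ring. They also leave open how a carboxylic acid or a dimethylamine on that ring, or a methylene or sulfonamide link at the same place, would read in this assay.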